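The compounds below may be only part of what the source reports. "The series", "measured", "known", "first", "only" and "open" are said of these compounds alone.

Among the measured compounds shown here, in an ADME assay on CHO cells (Cricetulus griseus) for inhibition, read by MTT assay (a lower number here means a stronger inhibitor, a higher number a weaker inhibitor), compound 3 (`CCNCc1cc(Cl)cc(Nc2nc3ccccc3n2Cc2ccc(C(F)(F)F)cc2)c1O`) gives 33800 nM as the only true number in the set. Compound 1 (`CCN(CC)Cc1cc(Cl)cc(Nc2nc3ccccc3n2Cc2ccc(C(F)(F)F)cc2)c1O`) gives > 50000 nM as a limit of the assay and not a number. Compound 2 (`CC(C)(C)NCc1cc(Cl)cc(Nc2nc3ccccc3[nH]2)c1O`) gives > 50000 nM as a limit as well.

The change from compound 3 to compound 4 (`CCNCc1cc(Cl)cc(Nc2nc3ccccc3[nH]2)c1O`) is hydrogen in place of 4-(trifluoromethyl)benzyl on an aromatic nitrogen and nothing else. For the measured compounds named here, the one measured step, hydrogen in place of ethyl on an amine nitrogen, is an at least 1.4-fold lower number from compound 1 to compound 3 (0.17 log units; that floor lies within the scatter) and it sits at another place in the structure, so it gives no size for this change. The nearest guide is compound 2, which also carries hydrogen on that aromatic nitrogen and reads > 50000 nM as a limit. A modest move toward a higher number in this assay is therefore expected, and a report of a limit alone would fit the limit of > 50000 nM in this assay, at which 2 of the 3 values shown sit, in this set. The expected change is a 1.6-fold higher number from compound 3 to compound 4 (0.21 log units; within the scatter) and it remains only an estimate. For compound 4 the estimate is 55000 nM with 28000 nM to 120000 nM as the expected range.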

Compound 4, half-maximal inhibitory concentration in the CHO assay: > 50000 nM
Compound 4: a limit, no number (the forecaster's own chance of this, stated with the estimate: 75%); the middle value lies beyond the limit too.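

Among the compounds shown here, in the CHO assay, hydrogen in place of 4-(trifluoromethyl)benzyl on the aromatic nitrogen gives an at least 1.4-fold higher number from compound 3 to compound 4 (0.17 log units; that floor lies within the scatter), the first direct reading of this position, with ethyl kept on the amine nitrogen; it is only a floor, so the size of the change remains unknown and no real shift can be claimed from it. Compound 2 and compound 4 both stand at a limit, so the step between them cannot be read, and the swap of tert-butyl for ethyl on the amine nitrogen gains no size here. The same change at the aromatic nitrogen does show clearly in a physicochemical assay for solubility, read by HPLC, measured as kinetic solubility, with a stated time of 24 h, at pH 6.5 (on this read-out higher numbers stand for higher solubility and lower numbers for lower solubility), where compound 3 gives 12000 nM and compound 4 gives 200000 nM and losing the 4-(trifluoromethyl)benzyl goes with much higher solubility: the measured solubility of compound 3, 12000 nM, and of compound 4, 200000 nM, a 17-fold higher number (1.22 log units; beyond the scatter)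

With most readings in the CHO assay at one limit, the compounds shown leave open how far this position can move that read-out at all: the limit of > 50000 nM in the CHO assay, at which 3 of the 4 values shown sit. It also remains open how a methyl group on that aromatic nitrogen, or a benzyl group bearing a carboxylic acid or an amine in place of trifluoromethyl, would read in the CHO assay and in the physicochemical assay.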